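A few compounds are considered here, and "the series" means these few. Any claim that something is new, unique, unknown or untested is made for them only; others in the source may bear on it.

Compound 1 `CN(C)c1nc(N)nc2c1ncn2/C=C1/CC1(CO)CO`: > 300000 nM
Compound 2 `CCCCOc1nc(N)nc2c1ncn2/C=C1/CC1(CO)CO`: > 300000 nM

In an ADME assay on HFF cells (Homo sapiens) for cytotoxicity, with a stated time of 8 days (a higher number here means that more compound is tolerated, a lower number that less compound is tolerated), compound 2 gives > 300000 nM, which is a limit and not a number. Compound 1 gives > 300000 nM, which is also a limit. Compound 3 `CCCCSc1nc(N)nc2c1ncn2/C=C1/CC1(CO)CO` differs from compound 2 by one change: butylsulfanyl in place of butoxy on an aromatic carbon. Going by the values given here, the only measured step that bears on this change is a step that the two limits leave unreadable from compound 1 to compound 2, so it sets no size. All the data here are the limit of > 300000 nM in this assay, at which 2 of the 2 values shown sit. With no readable step to go on, only a small change is expected in this assay, and compound 3 will probably stay close to that limit, perhaps reading slightly lower. The expected change is an at least 1.2-fold lower number from compound 2 to compound 3 (0.07 log units; that floor lies within the scatter). For compound 3 the estimated value is 250000 nM, within an expected range from 90000 nM to 300000 nM.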

Compound 3, half-maximal cytotoxic concentration: > 300000 nM
Compound 3 was reported as a limit (the forecaster's own chance of this, stated with the estimate: 60%); at least 1.2-fold (0.07 log units) between middle value and limit.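

In this assay, going by these compounds alone, compound 1, compound 2 and compound 3 each give only a limit, not a number, and no step between them can be read. As far as these compounds go, how far each compound lies past that limit, and whether dimethylamino, butoxy and butylsulfanyl differ at all, stays open.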